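A few compounds are considered here, and "the series" means these few. Any claim that something is new, unique, unknown or untested is made for them only; others in the source may bear on it.

Measured compounds:
- compound 1, `Cc1ccc(OCCCON2C(N)=NC(N)=NC23CCOCC3)cc1`: > 90%
- compound 2, `NC1=NC2(CCOCC2)N(OCCCOc2cccc(Cl)c2Cl)C(N)=N1`: 81.7%

In an assay on isolated protein for inhibition of Dihydrofolate reductase (Homo sapiens), read by spectrophotometry, using NADPH, with stated times of 5 s and 6 min, tested at 5 uM (a lower number here means a weaker effect, a higher number a stronger effect of the compound at the concentration tested), compound 1 reaches only a limit of the assay, > 90%. Compound 2 gives 81.7% in this assay, the only plain number shown, the other value being (the limit of > 90% in this assay, at which 1 of the 2 values shown sits). Going by the values given here, the one measured step, a number at least 8.3 percentage points lower from compound 1 to compound 2 (that floor lies within the scatter), lies within the scatter.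

Compound 3, `NC1=NC2(CCOCC2)N(OCCCOc2ccccc2Cl)C(N)=N1`, differs from compound 2 by hydrogen in place of chloro on an aromatic carbon. That step bears on the same ring as the measured one, which changed the read-out only within the scatter, so no shift beyond the scatter is expected. Compound 3 is therefore estimated at 80%, with a range of 60% to 92%. The expected step is a number 1.7 percentage points lower from compound 2 to compound 3 (within the scatter).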

Compound 3, a percentage reported as inhibition, at one concentration (the size of the read-out at that concentration, not a potency): 83.3%
Compound 3: the middle estimate sits 3.3 percentage points below what was measured; the range from low to high includes it.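

Going from 2,3-dichlorophenyl to 2-chlorophenyl gives a number 1.6 percentage points higher from compound 2 to compound 3 (within the scatter), so at this position on the aromatic ring, this assay does not separate hydrogen from chloro. The remaining chloro group is still present in compound 3, so this step says nothing about a ring with no chloro at all. The comparison with the 4-methylphenyl compound gives a number at least 6.7 percentage points lower from compound 1 to compound 3 (that floor lies within the scatter), and this remains only a floor: the limit of > 90% in this assay, at which 1 of the 3 values shown sits.

The compounds shown leave open whether an amine or a methoxy group at this position would move the read-out beyond the scatter. They also leave open how a fully unsubstituted phenyl ring would compare.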